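Swapping Phenyl for Tert-Butoxycarbonyl on the Piperazine

The compounds below may be only part of what the source reports. "The series", "measured", "known", "first", "only" and "open" are said of these compounds alone.

Of the compounds shown here, three built on a shared core have been tested in a functional assay on MCF7 cells (Homo sapiens) for inhibition, read by MTT assay; on this read-out lower numbers stand for stronger inhibition and higher numbers for weaker inhibition. Compound 1, `CCCCCCCCn1cc(/C=C/C(=O)c2ccc(NC(=O)CN3CCN(c4ccccc4)CC3)cc2)nn1`, gives 31900 nM in this assay. Compound 2, `CCCCCCCCCCn1cc(/C=C/C(=O)c2ccc(NC(=O)CN3CCN(c4ccccc4)CC3)cc2)nn1`, reaches only a limit of the assay, > 100000 nM, so no number is known for it. Compound 3, `CCCCCCCCCCn1cc(/C=C/C(=O)c2ccc(NC(=O)CBr)cc2)nn1`, gives 9760 nM in this assay. Putting ethyl in place of hydrogen on the chain produced an at least 3.1-fold higher number from compound 1 to compound 2 (0.49 log units; beyond the scatter), and replacing the phenylpiperazinyl group by bromo produced an at least 10-fold lower number from compound 2 to compound 3 (1.01 log units; beyond the scatter). Compound 2 thus sits at the weak end of what is known, and the second step shows that the group on the carbon next to the amide carbonyl moves the numbers a great deal.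

Compound 4, `CCCCCCCCCCn1cc(/C=C/C(=O)c2ccc(NC(=O)CN3CCN(C(=O)OC(C)(C)C)CC3)cc2)nn1`, differs from compound 2 by tert-butoxycarbonyl in place of phenyl on an amine nitrogen in a ring. Going by the values given here, no measured step exchanges one substituent on that ring nitrogen for another, so the only guide is that compound 2 stands at a limit, with room to move downward but little upward. Compound 4 is therefore expected to give about 50000 nM in this assay, within 10000 nM to 150000 nM. That estimate means a step of an at least 2.0-fold lower number from compound 2 to compound 4 (0.30 log units; that floor lies within the scatter), expected to be a modest lowering at best, and a limit may again be reported.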

Compound 4, half-maximal inhibitory concentration: 40000 nM
Compound 4: the middle estimate sits 1.3-fold (0.10 log units) above what was measured, and the stated range covers the measured number.
By their numbers in this assay, from the lowest: compound 3; then compounds 1 and 4 (each within the scatter of the next). At a limit, above all of these: compound 2.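

Tert-butoxycarbonyl in place of phenyl on the amine nitrogen in the ring gave an at least 2.5-fold lower number from compound 2 to compound 4 (0.39 log units; beyond the scatter) in this assay, the first sign that the substituent on this nitrogen alone can move the number while the rest of the structure stays the same. The earlier steps shown here had changed the chain or removed the whole 4-phenylpiperazin-1-yl group, so they could not separate this nitrogen substituent from the ring that carries it. Compound 2 stands at a limit of the assay, so this step gives only a floor and its true size remains unknown: the limit of > 100000 nM in this assay, at which 1 of the 4 values shown sits.

The compounds shown leave open what a free amine, an acetyl group or a benzyl group on that ring nitrogen would give in this assay, and so whether the lower number follows from losing the aromatic ring, from gaining the carbonyl or from something else in tert-butoxycarbonyl. Also open, from the compounds shown here alone, is whether the same exchange would lower the number on the shorter chain of compound 1.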